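The source may hold more compounds than are shown below. What is called first, only, known or untested is meant among the compounds shown, and "the series" means these compounds.

Measured compounds:
Compound 1 `CCCn1c(=O)c2nc(-c3cnn(Cc4c(F)cccc4F)c3)[nH]c2n(CCC)c1=O` — in an in vitro assay on HEK293 cells for displacement of a labelled ligand from adenosine receptor A2b (Homo sapiens) (on this read-out higher numbers stand for weaker inhibition and lower numbers for stronger inhibition), compound 1 gives 390 nM.
Compound 2 `CCCn1c(=O)c2nc(-c3cnn(-c4ccc(Cl)cc4)c3C(F)(F)F)[nH]c2n(CCC)c1=O` — in this assay compound 2 gives only a limit of the assay, > 6600 nM.

Compound 1 thus stands as the sole measured number in this assay among the two compounds shown. The reading for compound 2 is a limit and not a number, which is all that can be said of it; the evidence notes (the limit of > 6600 nM in this assay, at which 1 of the 2 values shown sits). Among the compounds with values here, no step between the two measured compounds is counted, since they differ in more than one place, so their two values can only be set side by side.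

Compound 3 `CCCn1c(=O)c2nc(-c3cnn(Cc4c(F)cc(F)cc4F)c3)[nH]c2n(CCC)c1=O` is not yet measured. It differs from compound 1 by fluoro in place of hydrogen on an aromatic carbon, turning the 2,6-difluorobenzyl group into a 2,4,6-trifluorobenzyl group. Within the data shown here, with no measured step of this kind to draw on, a small change is expected, not beyond the scatter, and the step from compound 1 to compound 3 is estimated as a 1.0-fold higher number from compound 1 to compound 3 (0.01 log units; within the scatter). Compound 3 is therefore expected to give about 400 nM in this assay, within a range of 150 nM to 1100 nM.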

Compound 3, inhibition constant: 650 nM
Beside the measured number, compound 3's estimate is 1.6-fold (0.21 log units) below it, within the range that was stated.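

In this assay, replacing hydrogen with fluoro on the aromatic carbon that is para to a large group and meta to two fluoro groups, which turns the 2,6-difluorobenzyl group into a 2,4,6-trifluorobenzyl group, gives a 1.7-fold higher number from compound 1 to compound 3 (0.22 log units; within the scatter). This is the first change in one place among the compounds shown, and it shows that this carbon can carry a fluoro without a step that can be told from the usual scatter, so compound 3 and compound 1 read as alike on this read-out. Nothing in the available evidence bears on this result.

What the compounds shown leave open is whether this tolerance extends beyond fluoro to a chloro, a methoxy, an amine or a carboxylic acid on the same carbon, and whether the 2,6-difluoro pattern itself matters, since both compounds in the step carry it. Within the data shown here, compound 2 gives > 6600 nM, which is a limit of the assay, and it offers no step to set with this one.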